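The source may hold more compounds than are shown below. What is called first, only, known or untested is meant among the compounds shown, and "the series" means these compounds.

Measured in an in vitro ADME assay on microsomes (Mus musculus) for metabolic stability; a higher number here means that the compound lasts longer, a lower number that the compound disappears faster:
- compound 1 `CNC(=O)Nc1ccc(-c2nc(N3CC4CCC(C3)O4)c3cnn(C(C)C)c3n2)cc1`: > 0.5 h
- compound 2 `CNC(=O)Nc1ccc(-c2nc(N3CC4CCC(C3)O4)c3cnn(C)c3n2)cc1`: > 0.5 h

In this assay compound 2 gives > 0.5 h, which is a limit of the assay and not a number. Compound 1 gives > 0.5 h, and this too is a limit. Compound 2 therefore stands at the limit of > 0.5 h in this assay, at which 2 of the 2 values shown sit.

The next compound, compound 3 `CNC(=O)Nc1ccc(-c2nc(N3CC4CCC(C3)O4)c3cnn(CCN(C)C)c3n2)cc1`, keeps the shared core of compound 2 and changes one group: (dimethylamino)methyl in place of hydrogen on a saturated chain carbon bound to an aromatic nitrogen. Put more simply, a methyl becomes a 2-(dimethylamino)ethyl on the aromatic nitrogen.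

Going by the values given here, only one measured step bears on this change, since it also alters the group on an aromatic nitrogen. That step, a step that the two limits leave unreadable from compound 1 to compound 2, has no readable size, so it offers no number to carry over. It shows only that methyl and isopropyl both reach the same limit. With so little to go on, the expected step is an at least 1.1-fold lower number from compound 2 to compound 3 (0.04 log units; that floor lies within the scatter), which means no expected move beyond the usual scatter, in either direction. For compound 3 the estimated half-life is 0.45 h, with an expected range from 0.2 h to 0.9 h.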

Compound 3, half-life: 0.0833 h
Compound 3: middle estimate off by 5.4-fold (0.73 log units), on the high side; the measured number lies below the stated range.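

The group on an aromatic nitrogen turns out to matter in this assay, which the two earlier compounds could not show: with 2-(dimethylamino)ethyl in place of methyl, the result is an at least 6.0-fold lower number from compound 2 to compound 3 (0.77 log units; beyond the scatter), and with the same group in place of isopropyl, it is an at least 6.0-fold lower number from compound 1 to compound 3 (0.77 log units; beyond the scatter). Among the three compounds, only compound 3 gives a readable number rather than a limit of the assay, and a lower number here means that a compound disappears faster. Both steps are stated as minimum sizes and the real drops may be larger, because their starting values are limits and not numbers: the limit of > 0.5 h in this assay, at which 2 of the 3 values shown sit.

The compounds shown leave open whether the drop belongs to the dimethylamino end of the new group or to the longer chain alone, and a 2-methoxyethyl group on the same aromatic nitrogen would help to separate the two. From the compounds shown here alone, the step between compound 1 and compound 2 cannot be read, so any difference between isopropyl and methyl at this position also remains open.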